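From Fluoro to Bromo on the Shared Core

The source may report more compounds than this note shows. Statements on the series, on what has been measured and on what is new or still open speak of the compounds shown alone.

In a functional assay on L1210 cells (Mus musculus) for inhibition (on this read-out higher numbers stand for weaker inhibition and lower numbers for stronger inhibition), compound 1 `O=C1/C(=C/c2ccc(F)cc2)Cc2ccccc21` gives 89000 nM and compound 2 `O=C1/C(=C/c2cccc(F)c2)CCc2ccccc21` gives 61200 nM while compound 3 `O=C1/C(=C/c2ccc(F)cc2)CCc2ccccc21` gives 49300 nM as its reading. All three numbers lie within the usual scatter of one another, so compound 3 stands level with the other two.

Compound 4 `O=C1/C(=C/c2ccc(Br)cc2)CCc2ccccc21` is still unmeasured and has one change from compound 3 (bromo in place of fluoro on an aromatic carbon) with bromo in place of fluoro on an aromatic carbon. Going by the values given here, no measured pair shows this swap. Given how closely compound 2 at 61200 nM and compound 3 at 49300 nM agree, only a slight move toward a lower number is expected in this assay and none beyond the scatter. The expected step is a 1.2-fold lower number from compound 3 to compound 4 (0.09 log units; within the scatter) and no more. Compound 4 is estimated at 40000 nM and expected to fall from 18000 nM to 85000 nM on repeated testing.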

Compound 4, half-maximal inhibitory concentration: 202000 nM
Estimate against measurement, compound 4: 5.1-fold (0.70 log units) below; the measured number lies above the stated range.
By their numbers in this assay, from the lowest: compounds 3, 2 and 1 (each within the scatter of the next); then compound 4.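

Bromo in place of fluoro on this aromatic carbon is not a neutral swap: in this assay it gives a 4.1-fold higher number from compound 3 to compound 4 (0.61 log units; beyond the scatter) and so weakens inhibition. Going by these compounds alone, the earlier compounds all read level with one another, so this is the first sign that a change at this position can move the number beyond the scatter. No measurement at hand explains the shift.

On these data alone, whether chloro, methoxy or an amine at this position would stay level with compound 3 or move toward compound 4 remains open. So does whether the same swap would have a similar effect on the core of compound 1.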